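Notes on the aryl substituent: series summary and next step

The source may hold more compounds than are shown below. What is called first, only, known or untested is meant among the compounds shown, and "the series" means these compounds.

Measured in a functional assay for inhibition, tested at 40 ug/mL; on this read-out lower numbers stand for a weaker effect and higher numbers for a stronger effect at the one concentration tested:
- compound 1, `Cc1cc(O)c(C(C)C)cc1-c1cc(-c2cccs2)c(C#N)c(=O)[nH]1`: 41%
- compound 2, `Cc1cc(O)c(C(C)C)cc1-c1cc(-c2ccco2)c(C#N)c(=O)[nH]1`: 42.5%
- compound 3, `COc1ccc(-c2cc(-c3cc(C(C)C)c(O)cc3C)[nH]c(=O)c2C#N)cc1OC`: 44%

All three share one core and differ only in the aryl group on the ring carbon ortho to the cyano group. The steps between them are small: a number 1.5 percentage points higher from compound 1 to compound 2 (within the scatter), a number 3 percentage points higher from compound 1 to compound 3 (within the scatter) and a number 1.5 percentage points higher from compound 2 to compound 3 (within the scatter). Compound 3 holds the highest of the three numbers in this assay , but its nearest neighbour compound 2 and its furthest neighbour compound 1 both lie within the scatter of it, so no order among the three can be read.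

Compound 4, `Cc1cc(O)c(C(C)C)cc1-c1cc(-c2ccc(N(C)C)cc2)c(C#N)c(=O)[nH]1`, is not yet measured. Compared with compound 3 the change is 4-(dimethylamino)phenyl in place of 3,4-dimethoxyphenyl on an aromatic carbon. Among the measured compounds shown here, no measured step covers this exchange; the three measured steps only show that swapping thiophen-2-yl, furan-2-yl and 3,4-dimethoxyphenyl at this position left the read-out flat. On that basis the expected step is a number 1 percentage points lower from compound 3 to compound 4 (within the scatter), that is, none beyond the scatter. The estimate for compound 4 in this assay is therefore 43%, with a range from 33% to 53%.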

Compound 4, a percentage reported as inhibition, at one concentration (the size of the read-out at that concentration, not a potency): 43%
Beside the measured number, compound 4's estimate shows no gap at the digits printed; the measured number falls inside the stated range.
By their numbers in this assay, from the lowest: compounds 1, 2, 4 and 3 (each within the scatter of the next).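

In this assay the 4-(dimethylamino)phenyl group gives a number 1 percentage points lower from compound 3 to compound 4 (within the scatter), a number 0.5 percentage points higher from compound 2 to compound 4 (within the scatter) and a number 2 percentage points higher from compound 1 to compound 4 (within the scatter), so all three new steps stay inside the scatter. The flat read-out at this position, ortho to the cyano group, now extends to an aryl group carrying a nitrogen substituent, which the thiophen-2-yl, furan-2-yl and 3,4-dimethoxyphenyl compounds did not cover, and it holds for the exchange of 3,4-dimethoxyphenyl for 4-(dimethylamino)phenyl, in which the hydrogen-bond acceptors go from 2 to 1. No supporting measurement bears on why the read-out stays level across these groups.

Open is whether anything at this position moves the read-out beyond the scatter, since all four groups shown are aromatic rings: a carboxylic acid on the phenyl ring, a saturated amine such as morpholine or a plain alkyl chain in place of the ring could each test that. Also open is how the effect of these compounds compares at other concentrations, as the single concentration gives only the size of the effect at that concentration.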